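Pyrrole Replaces Carboxyphenyl at the Activity Floor

A few compounds are considered here, and "the series" means these few. Any claim that something is new, unique, unknown or untested is made for them only; others in the source may bear on it.

Three compounds share one core and differ only in the aromatic group on the double-bonded chain carbon. Within the data shown here, compound 1 `CCOC(=O)C1=C(Nc2ccccc2)S/C(=C\c2ccc(OC)cc2)C1=O` is the only one with a reported number: in a functional assay on MCF7 cells (Homo sapiens) for inhibition, read by MTT assay, with a stated time of 72 h, tested at 10 uM (on this read-out higher numbers stand for more inhibition at the one concentration tested (going by the name of the read-out) and lower numbers for less inhibition), compound 1 gives 14.7%. Compound 2 `CCOC(=O)C1=C(Nc2ccccc2)S/C(=C\c2ccc(C(=O)O)cc2)C1=O` reaches only a limit of the assay, and in this assay compound 2 shows < 10%. Compound 3 `CCOC(=O)C1=C(Nc2ccccc2)S/C(=C\c2cccc(C(=O)O)c2)C1=O` likewise sits at a limit, and in this assay compound 3 shows < 10%. The step of a number at least 4.7 percentage points lower from compound 1 to compound 2 (that floor lies within the scatter) and the step of a number at least 4.7 percentage points lower from compound 1 to compound 3 (that floor lies within the scatter) are both recorded, while the step that the two limits leave unreadable from compound 2 to compound 3 has no readable size. Compound 3 thus stands at the limit of < 10% in this assay, at which 2 of the 3 values shown sit.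

Compound 4 `CCOC(=O)C1=C(Nc2ccccc2)S/C(=C\c2cc[nH]c2)C1=O` carries a new group: 1H-pyrrol-3-yl in place of 3-carboxyphenyl on a double-bonded chain carbon bound to a double-bonded ring carbon. Among the measured compounds shown here, no measured step involves a pyrrole, so the earlier steps bear only indirectly, showing that swapping the aromatic group moved the read-out by small amounts close to the limit. In this assay no step beyond the scatter is expected, a number no lower from compound 3 to compound 4 (the limit leaves the size open). Compound 4 is estimated at 10%, between 0% and 25%.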

Compound 4, a percentage reported as inhibition, at one concentration (the size of the read-out at that concentration, not a potency): < 10%
Compound 4: no number, only a limit (the forecaster's own chance of this, stated with the estimate: 55%); the middle value sits exactly at the limit.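

In this assay compound 4 gives < 10%, which is a limit and not a number. A small five-membered pyrrole ring with no carboxy group therefore ends at the same limit as the two carboxyphenyl compounds, so a carboxy group is not needed to reach it at this position: the limit of < 10% in this assay, at which 3 of the 4 values shown sit.

Among these compounds, the one readable step is a number at least 4.7 percentage points lower from compound 1 to compound 4 (that floor lies within the scatter), and the steps to compound 4 from the two carboxyphenyl compounds cannot be read.

Still open, as far as these compounds go, is whether any group on this double-bonded chain carbon can lift the read-out clearly beyond the scatter, given that only the methoxy compound has a number at all. The compounds shown also do not tell how an amine on the phenyl ring, such as 4-aminophenyl, would behave here.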